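The source may hold more compounds than are shown below. What is called first, only, known or untested is meant among the compounds shown, and "the series" means these compounds.

Measured so far in a functional assay on KB cells (Homo sapiens) for inhibition, read by sulforhodamine B assay; on this read-out higher numbers stand for weaker inhibition of growth and lower numbers for stronger inhibition of growth:
compound 1, `Cc1ccc2[nH]c(-c3ccc(-c4ccc(-c5cccc(Cl)c5)cc4)cc3)nc2c1`, gives 2260 nM
compound 2, `COc1ccc(-c2ccc(-c3ccc(-c4nc5cc(C)ccc5[nH]4)cc3)cc2)cc1OC`, gives 2190 nM
compound 3, `Clc1cccc(-c2ccc(-c3ccc(-c4nc5ccccc5[nH]4)cc3)cc2)c1`, gives 32300 nM

Compounds 1 and 2 share one core, compound 3 carries the other; the two cores differ by hydrogen in place of methyl on an aromatic carbon. That change alone gives a 14-fold higher number from compound 1 to compound 3 (1.16 log units; beyond the scatter), so compound 3 has the highest number of the three measured compounds, beyond the scatter against both compound 1 and compound 2.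

Compound 4, `COc1ccc(-c2ccc(-c3ccc(-c4nc5ccccc5[nH]4)cc3)cc2)cc1OC`, has not yet been measured in this assay. It pairs the core of compound 3 with the terminal group of compound 2. The change from compound 3 to compound 4 is 3,4-dimethoxyphenyl in place of 3-chlorophenyl on an aromatic carbon. The same change has already been made once, from compound 1 to compound 2, as 3,4-dimethoxyphenyl in place of 3-chlorophenyl on an aromatic carbon, where it gave a 1.0-fold lower number from compound 1 to compound 2 (0.01 log units; within the scatter). The surroundings of the place are described in the same words for both pairs, so this is the same change, not merely the same kind.

Among the compounds with values here, only that one measured pair supports a forecast. The step is expected to be a 1.1-fold lower number from compound 3 to compound 4 (0.03 log units; within the scatter), again within the scatter, because the step from compound 1 to compound 2 in this assay was a 1.0-fold lower number from compound 1 to compound 2 (0.01 log units; within the scatter). Compound 4 is therefore estimated at 30000 nM in this assay. Within the data shown here, the range for compound 4 is expected to run from 10000 nM to 90000 nM, the width reflecting that only one prior instance of the change exists and that the number for compound 3 is itself high.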

Compound 4, concentration for 50% growth inhibition: 9250 nM
Estimate against measurement, compound 4: 3.2-fold (0.51 log units) above; measured number below the stated range.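

In this assay the step to 3,4-dimethoxyphenyl in place of 3-chlorophenyl is a 3.5-fold lower number from compound 3 to compound 4 (0.54 log units; beyond the scatter), and the change does not carry over from one core to the other with the same size: the same change on two cores in this assay, a 1.0-fold lower number (0.01 log units; within the scatter) from compound 1 to compound 2 and a 3.5-fold lower number (0.54 log units; beyond the scatter) from compound 3 to compound 4, 3.4-fold (0.53 log units) apart, beyond the scatter of two such steps. Read the other way, hydrogen in place of methyl gives a 4.2-fold higher number from compound 2 to compound 4 (0.63 log units; beyond the scatter), and with 3,4-dimethoxyphenyl as terminal group this step is smaller than with 3-chlorophenyl, so in these compounds the effect of the terminal group and that of the methyl cannot be added up independently: the same change on two cores in this assay, a 14-fold higher number (1.16 log units; beyond the scatter) from compound 1 to compound 3 and a 4.2-fold higher number (0.63 log units; beyond the scatter) from compound 2 to compound 4, 3.4-fold (0.53 log units) apart, beyond the scatter of two such steps. Compounds 1, 2, 3 and 4 form one closed set, so the two gaps are a single observation seen from two sides; it does not give a reason for the gap, and it does not show how any other core or terminal group would behave.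

The compounds shown leave open whether a terminal ring carrying an amine or a carboxylic acid would depend on the core in the same way. They also leave open whether an ethyl group or a chlorine in place of the methyl would give the same dependence.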